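The source may hold more compounds than are shown below. What is called first, only, known or untested is meant among the compounds shown, and "the series" means these compounds.

Within the data shown here, in a functional assay on the whole organism for inhibition, with Mus musculus as the target (a higher number here means that more compound is needed for the effect, a lower number that less compound is needed), compound 2 (`CC(C)NCCC(=O)Nc1cccc2c1CN(C)CC2c1ccccc1`) stands at about 125 mg/kg, the higher of the two numbers available so far. Compound 1 (`CCCCNC(=O)Nc1cccc2c1CN(C)CC2c1ccccc1`) gives 23 mg/kg, so less of compound 1 is needed for the effect. Compound 3 (`CCCCNCCC(=O)Nc1cccc2c1CN(C)CC2c1ccccc1`) has not been measured yet. It differs from compound 2 in one place: butyl in place of isopropyl on an amine nitrogen, which means butyl in place of isopropyl on an amine nitrogen.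

Among the measured compounds shown here, only one measured step bears on this change, a 5.4-fold higher number from compound 1 to compound 2 (0.74 log units; beyond the scatter). It is an imperfect guide, since it replaces butylamino on a carbonyl carbon with 2-(isopropylamino)ethyl and so alters more than the butyl group alone. Compound 3 regains the butyl of compound 1 but keeps the rest of the chain of compound 2. The data cannot show how much of the measured step goes with the butyl, so only a small part of it is expected to return, in the direction of a lower number. The expected step is a 1.5-fold lower number from compound 2 to compound 3 (0.17 log units; within the scatter). Compound 3 is estimated at 85 mg/kg, with an expected range from 35 mg/kg to 200 mg/kg.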

Compound 3, dose for half-maximal effect: 74 mg/kg
Compound 3: the middle estimate sits 1.1-fold (0.06 log units) above what was measured; measured number inside the range.
By their numbers in this assay, from the lowest: compound 1; then compounds 3 and 2 (each within the scatter of the next).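

In this assay, butyl in place of isopropyl on an amine nitrogen gives a 1.7-fold lower number from compound 2 to compound 3 (0.23 log units; within the scatter), so at this position the two groups cannot be told apart, and a straight chain serves no differently from a branched one in this pair. The comparison with compound 1 separates what the earlier step had mixed together: with butyl present in both compounds, 2-(butylamino)ethyl in place of butylamino on a carbonyl carbon still gives a 3.2-fold higher number from compound 1 to compound 3 (0.51 log units; beyond the scatter), so most of the earlier gap goes with this change of the chain on the carbonyl carbon, and little of it goes with the butyl group itself. No measurement here explains why the number moves with that change.

On these data alone, it remains open whether this amine nitrogen tolerates any group in this assay or only small alkyl groups like these two, and a longer chain such as hexyl or a benzyl group would test that. As far as these compounds go, it is also open whether a chain of intermediate length, such as (butylamino)methyl on the carbonyl carbon, would fall nearer to compound 1 or to compound 3.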